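Trifluoromethyl for tert-Butyl on the Weakest Aminophenyl Analogue

A few compounds are considered here, and "the series" means these few. Any claim that something is new, unique, unknown or untested is made for them only; others in the source may bear on it.

Compound 3 `CC(C)(C)c1ccc(CN2C(=O)S/C(=C\c3cccc(N)c3)C2=O)cc1` stands with the highest number of the three compounds measured in a functional assay on HeLa cells (Homo sapiens) for cytotoxicity, read by cell counting, with a stated time of 4 days; on this read-out lower numbers stand for stronger inhibition and higher numbers for weaker inhibition: compound 3 gives 145000 nM. Its nearest neighbour is compound 1 `CC(C)(C)c1ccc(CN2C(=O)S/C(=C\c3ccc(N)cc3)C2=O)cc1`, which in this assay gives 53000 nM. The two differ only in 3-aminophenyl against 4-aminophenyl, and a 2.7-fold higher number from compound 1 to compound 3 (0.44 log units; beyond the scatter). Among the measured compounds shown here, compound 2 `C=C(Br)C(=O)Nc1ccc(/C=C2\SC(=O)N(Cc3cccc(F)c3)C2=O)cc1` is the furthest away, giving 5900 nM in this assay, but it carries more than one change relative to compound 3 and no single step links the pair. Compound 4 `Nc1cccc(/C=C2\SC(=O)N(Cc3ccc(C(F)(F)F)cc3)C2=O)c1` differs from compound 3 in one place: trifluoromethyl in place of tert-butyl on an aromatic carbon. No measured pair differs in this same way, so nothing among these data speaks directly to the exchange, while the 3-aminophenyl end that set compound 3 apart is untouched. One therefore expects compound 4 to stay close to compound 3, with an expected step of a 1.1-fold lower number from compound 3 to compound 4 (0.05 log units; within the scatter) that need not exceed the usual scatter. Compound 4 is estimated at 130000 nM, with a range from 45000 nM to 380000 nM.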

Compound 4, half-maximal inhibitory concentration: > 250000 nM
Compound 4 was reported as a limit; the forecaster's own chance of this, stated with the estimate: 25%; middle value at least 1.9-fold (0.28 log units) from the limit.
By their numbers in this assay, from the lowest: compound 2; then compound 1; then compound 3. At a limit, above all of these: compound 4.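

With the step of an at least 1.7-fold higher number from compound 3 to compound 4 (0.23 log units; that floor lies within the scatter), the exchange of tert-butyl for trifluoromethyl on this aromatic carbon brings no lower number in this assay, though the floor of that step does not establish a real rise. Among the compounds shown here, until now, the only single change that could be read lay at the aminophenyl end, so this is the first reading from the other end of the molecule. Compound 4 is reported only as a limit, so the true size of the step stays unknown: the limit of > 250000 nM in this assay, at which 1 of the 4 values shown sits.

The compounds shown leave open whether the same exchange would read alike with the 4-aminophenyl end of compound 1. They also leave open how a methoxy group or a carboxylic acid would read on this aromatic carbon.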